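Aryl hydrazone variation on the shared core

A few compounds are considered here, and "the series" means these few. Any claim that something is new, unique, unknown or untested is made for them only; others in the source may bear on it.

Measured so far in a functional assay on U-87MG ATCC cells (Homo sapiens) for cytotoxicity, read by MTT assay, with a stated time of 72 h; a lower number here means a stronger inhibitor, a higher number a weaker inhibitor:
compound 1 `CN(C)CCn1cnnc1-c1cc(Oc2ccc(NC(=O)N/N=C/c3c[nH]c4ccccc34)cc2F)ccn1` gives 690 nM.
compound 2 `CN(C)CCn1cnnc1-c1cc(Oc2ccc(NC(=O)N/N=C/c3ccc(O)c(Br)c3)cc2F)ccn1` gives 12400 nM.
compound 3 `CN(C)CCn1cnnc1-c1cc(Oc2ccc(NC(=O)N/N=C/c3ccccc3O[N+](=O)[O-])cc2F)ccn1` gives 7150 nM.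

Compound 3 stands second highest of the three numbers; nearest is compound 2, with a 1.7-fold lower number from compound 2 to compound 3 (0.24 log units; within the scatter); furthest is compound 1, with a 10-fold higher number from compound 1 to compound 3 (1.02 log units; beyond the scatter). Compound 4 `CN(C)CCn1cnnc1-c1cc(Oc2ccc(NC(=O)N/N=C/c3cc(Br)c(O)c(Br)c3)cc2F)ccn1` differs from compound 3 as follows: 3,5-dibromo-4-hydroxyphenyl in place of 2-(nitrooxy)phenyl on a carbon with a double bond to nitrogen. The step that bears on this is a 1.7-fold lower number from compound 2 to compound 3 (0.24 log units; within the scatter), since compound 2 already bears the 3-bromo-4-hydroxyphenyl. Within the data shown here, the large steps of an 18-fold higher number from compound 1 to compound 2 (1.25 log units; beyond the scatter) and a 10-fold higher number from compound 1 to compound 3 (1.02 log units; beyond the scatter) show only that both substituted phenyl groups fall well behind compound 1. Among the measured compounds shown here, no measured step separates 3-bromo-4-hydroxyphenyl from 3,5-dibromo-4-hydroxyphenyl. The expected step is therefore none beyond the scatter, a 1.4-fold higher number from compound 3 to compound 4 (0.15 log units; within the scatter). Compound 4 is estimated at 10000 nM, between 4000 nM and 25000 nM.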

Compound 4, half-maximal inhibitory concentration: > 100000 nM
Compound 4: only a limit was reported; the forecaster's own chance of this, stated with the estimate: 5%; middle value at least 10-fold (1.00 log units) from the limit.
By their numbers in this assay, from the lowest: compound 1; then compounds 3 and 2 (each within the scatter of the next). At a limit, above all of these: compound 4.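

Compound 4 carries a limit of the assay, not a number: the limit of > 100000 nM in this assay, at which 1 of the 4 values shown sits.

This position does not tolerate every halogen change on the phenyl: bromo in place of hydrogen on an aromatic carbon gives an at least 8.0-fold higher number from compound 2 to compound 4 (0.90 log units; beyond the scatter). With an at least 13-fold higher number from compound 3 to compound 4 (1.14 log units; beyond the scatter) and an at least 140-fold higher number from compound 1 to compound 4 (2.16 log units; beyond the scatter), the 3,5-dibromo-4-hydroxyphenyl falls behind every other group shown at this carbon, and all three steps are read against the limit.

Whether the second bromo alone accounts for this, or only does so together with the hydroxy, stays open. A 3,5-dibromophenyl without the hydroxy, or a 3,5-dichloro-4-hydroxyphenyl, would separate the two.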